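A Chloro Step Repeated on a Second Core

The source may hold more compounds than are shown below. What is called first, only, known or untested is meant among the compounds shown, and "the series" means these compounds.

Measured so far in a functional assay on HO8910 cells (Homo sapiens) for inhibition, read by MTT assay, with a stated time of 24 h, tested at 1 ug/mL; a lower number here means less inhibition of growth, a higher number more inhibition of growth at the concentration tested:
compound 1, `CC(=O)SCCC(CCCCC(=O)Nc1ccccc1)SC(C)=O`, gives 10.6%;
compound 2, `CC(=O)SCCC(CCCCC(=O)Nc1ccc(Cl)cc1)SC(C)=O`, gives 0.35%;
compound 3, `O=C(CCCCC(CCSC(=O)c1ccccc1)SC(=O)c1ccccc1)Nc1ccccc1`, gives 3.79%.

Compound 1 and compound 2 share one core and differ by chloro in place of hydrogen on an aromatic carbon. That change produced a number 10.3 percentage points lower from compound 1 to compound 2 (beyond the scatter). Compound 3 carries a different core; the difference between the two cores is not broken down here. Compound 3 and compound 2 show values within the scatter of each other, as do compound 3 and compound 1, so no order among them is claimed.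

Compound 4, `O=C(CCCCC(CCSC(=O)c1ccccc1)SC(=O)c1ccccc1)Nc1ccccc1Cl`, is not yet measured. It differs from compound 3 by chloro in place of hydrogen on an aromatic carbon. Within the data shown here, this is the same kind of change as the one from compound 1 to compound 2, but the place differs: there the chloro sits para to a large group, here it sits ortho to a large group.

In this assay compound 4 is expected to give 2%, between 0% and 12%. This rests on compound 3 at 3.79% and on the earlier step of a number 10.3 percentage points lower from compound 1 to compound 2 (beyond the scatter), which leaves little room to fall; the estimate means a number 1.8 percentage points lower from compound 3 to compound 4 (within the scatter).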

Compound 4, percent growth inhibition at one concentration: 2.35%
Compound 4: middle estimate off by 0.4 percentage points, on the low side; the measured number falls inside the stated range.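

In this assay, among these compounds, chloro in place of hydrogen on an aromatic carbon of the second core gives a number 1.4 percentage points lower from compound 3 to compound 4 (within the scatter), so on this core the change produces no step that stands clear of the usual variation. Set beside the step on the first core, the new step cannot be separated from it: the same change on two cores in this assay, a number 10.3 percentage points lower (beyond the scatter) from compound 1 to compound 2 and a number 1.4 percentage points lower (within the scatter) from compound 3 to compound 4, 8.8 percentage points apart, within the scatter of two such steps. This does not show that the change carries over from one core to the other with the same size: compound 3 already gives only 3.79%, and in compound 4 the chloro sits ortho to a large group, whereas compound 2 carries it at a different place on the ring.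

The compounds shown leave open whether chloro at one and the same place on both cores would give matching steps. They also leave open how a methoxy group, an amine or a carboxylic acid on this aromatic ring would read in this assay.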